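The compounds below may be only part of what the source reports. "The series", "measured", "known", "first", "only" and "open" are said of these compounds alone.

Compound 1 `CC(=O)Oc1ccc2oc(/C=C/[S+](C)[O-])cc(=O)c2c1` gives 4100 nM in a functional assay on A549 cells (Homo sapiens) for cytotoxicity, with a stated time of 48 h; a higher number here means a weaker inhibitor, a lower number a stronger inhibitor. Compound 2 `CC(C)CC(=O)Oc1ccc2oc(/C=C/[S+](C)[O-])cc(=O)c2c1` gives 2300 nM in this assay, the lowest of the two numbers, with compound 1 nearest; the step of a 1.8-fold lower number from compound 1 to compound 2 (0.25 log units; within the scatter) stays within the scatter. Compound 3 `C[S+]([O-])/C=C/c1cc(=O)c2cc(O)ccc2o1` differs from compound 2 by hydrogen in place of isobutylcarbonyl on an oxygen on an aromatic ring. Among the measured compounds shown here, the single measured step alters the saturated chain on the carbonyl carbon rather than removing the whole isobutylcarbonyl group, so it bears only loosely on this change; it was small, and no step beyond the scatter is expected, if anything a somewhat higher number. Compound 3 is estimated at 3500 nM in this assay, range 1200 nM to 10000 nM. The step expected is a 1.5-fold higher number from compound 2 to compound 3 (0.18 log units; within the scatter).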

Compound 3, half-maximal inhibitory concentration: 10500 nM
Compound 3: the middle estimate sits 3.0-fold (0.48 log units) below what was measured, and the stated range ends below it.
By their numbers in this assay, from the lowest: compounds 2 and 1 (each within the scatter of the next); then compound 3.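

On the oxygen on the aromatic ring, removing the whole acyl group counts for more than changing its chain. In this assay, hydrogen in place of isobutylcarbonyl gives a 4.6-fold higher number from compound 2 to compound 3 (0.66 log units; beyond the scatter), and hydrogen in place of acetyl gives a 2.6-fold higher number from compound 1 to compound 3 (0.41 log units; beyond the scatter), both beyond the scatter, while the chain change between the two esters stayed within it. No measurement at hand accounts for this shift. Going by these compounds, whether a methyl ether or a carbamate on this oxygen would keep the lower numbers stays open. So does the effect of a benzoyl group or a longer acyl chain.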